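A few compounds are considered here, and "the series" means these few. Any claim that something is new, unique, unknown or untested is made for them only; others in the source may bear on it.

Among the measured compounds shown here, compound 1 `COCOc1ccc(CN(Cc2ccc(C(C)(C)C)cc2)Cc2cc3cc(C)ccc3[nH]c2=O)cc1` is the first of two compounds tested in a toxicity assay on MDCK cells (Canis lupus familiaris) for cytotoxicity, read by crystal violet staining, with a stated time of 48 h (on this read-out lower numbers stand for higher toxicity in this test and higher numbers for lower toxicity in this test), where compound 1 gives 6400 nM. Compound 2 `Cc1ccc2[nH]c(=O)c(CN(Cc3ccc(N(C)C)cc3)Cc3ccc(C(C)(C)C)cc3)cc2c1` carries dimethylamino in place of methoxymethoxy on an aromatic carbon. In this assay compound 2 reaches only a limit of the test, > 5000 nM, so no exact number is known for it. The step that the limit leaves unreadable from compound 1 to compound 2 therefore cannot be sized, because of the limit of > 5000 nM in this assay, at which 1 of the 2 values shown sits. Compound 3 `Cc1ccc2[nH]c(=O)c(CN(Cc3ccc(C(C)(C)C)cc3)C(C)c3ccc(OC(F)F)cc3)cc2c1` is not yet measured. Its change from compound 2 is 1-(4-(difluoromethoxy)phenyl)ethyl in place of 4-(dimethylamino)benzyl on an amine nitrogen. For the measured compounds named here, only the one measured step bears on this change, and it is unreadable, so there is no ground to expect a shift beyond the usual scatter in either direction. The expected step is a step that the limit leaves unreadable from compound 2 to compound 3. Compound 3 is estimated at 7000 nM in this assay, in a range from 2500 nM to 25000 nM.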

Compound 3, half-maximal cytotoxic concentration: > 5000 nM
Compound 3: no number, only a limit; the forecaster's own chance of this, stated with the estimate: 45%; the middle value lies beyond the limit too.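

No new step can be read between compound 1, compound 2 and compound 3, because the results stop at a limit of the test: the limit of > 5000 nM in this assay, at which 2 of the 3 values shown sit. The compounds shown leave open how toxic compound 2 and compound 3 really are, and whether they differ from compound 1 or from each other.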